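Amide Variation and Macrophage Toxicity: Compound 4 Expected

The compounds below may be only part of what the source reports. "The series", "measured", "known", "first", "only" and "open" are said of these compounds alone.

Compound 1 `COc1ccc(-c2cnc(NC(=O)c3ccccc3OC)n2C)cc1` — in a toxicity assay on THP-1 cells (Homo sapiens) for inhibition (on this read-out higher numbers stand for lower toxicity in this test and lower numbers for higher toxicity in this test), compound 1 gives > 100000 nM, a limit of the assay.
Compound 2 `COc1ccc(-c2cnc(NC(=O)C3CCOCC3)n2C)cc1` — in this assay compound 2 gives > 100000 nM, also a limit.
Compound 3 `COc1ccc(-c2cnc(NC(=O)c3cnco3)n2C)cc1` — in this assay compound 3 gives > 100000 nM, again a limit.

Compound 3 thus stands at the limit of > 100000 nM in this assay, at which 3 of the 3 values shown sit. The steps a step that the two limits leave unreadable from compound 1 to compound 2, a step that the two limits leave unreadable from compound 1 to compound 3 and a step that the two limits leave unreadable from compound 2 to compound 3 all bear on the change to compound 4 `COc1ccc(-c2cnc(NC(=O)c3ccc(O)cc3)n2C)cc1`, which differs from compound 3 as follows: 4-hydroxyphenyl in place of 1,3-oxazol-5-yl on a carbonyl carbon. None of these steps is readable, so no size or direction beyond the scatter can be derived from them. Compound 4 is therefore expected to sit at the same limit, giving an estimated 100000 nM with a range from 40000 nM to 300000 nM, which means an expected step of a number no higher from compound 3 to compound 4 (the limit leaves the size open).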

Compound 4, half-maximal cytotoxic concentration: > 100000 nM
Compound 4 ended at the assay's limit (the forecaster's own chance of this, stated with the estimate: 85%); the middle value sits exactly at the limit.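

The steps to compound 4 from compound 1, compound 2 and compound 3 cannot be read, since all four compounds stand at a limit: the limit of > 100000 nM in this assay, at which 4 of the 4 values shown sit.

On these data alone, whether any change on the carbonyl carbon shifts the result in this assay at all stays open.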